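This account rests on a few compounds, and the source may have more. Where it says the series, first, only, none or still open, it means among the compounds named here.

Compound 1 `O=C(Nc1nc2ccc(Cl)cc2s1)c1cn(-c2ccccc2)nc1-c1ccc(F)cc1` and compound 3 `O=C(Nc1nc2ccc(Cl)cc2s1)c1cn(-c2ccccc2)nc1-c1ccc(Cl)cc1` are built on the same core; the difference between them is chloro in place of fluoro on an aromatic carbon. In a functional assay on A549 cells (Homo sapiens) for cytotoxicity, read by MTT assay, with a stated time of 72 h (on this read-out lower numbers stand for stronger inhibition and higher numbers for weaker inhibition), compound 1 gives 3870 nM. In this assay compound 3 gives 4360 nM. The step between them is a 1.1-fold higher number from compound 1 to compound 3 (0.05 log units; within the scatter), so the two cores are not separated by this read-out.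

Compound 2 `COc1ccc2nc(NC(=O)c3cn(-c4ccccc4)nc3-c3ccc(F)cc3)sc2c1` differs from compound 1 by methoxy in place of chloro on an aromatic carbon. In this assay compound 2 gives > 50000 nM, which is a limit of the assay and not a number. The step is therefore an at least 12-fold higher number from compound 1 to compound 2 (1.11 log units; beyond the scatter); its true size is open, because the limit of > 50000 nM in this assay, at which 1 of the 3 values shown sits, caps what the assay reports.

Compound 4 `COc1ccc2nc(NC(=O)c3cn(-c4ccccc4)nc3-c3ccc(Cl)cc3)sc2c1` has not yet been measured. It differs from compound 3 by methoxy in place of chloro on an aromatic carbon. The place of this change is described in the same words as for the change from compound 1 to compound 2, so it is the same change, made on the core of compound 3 instead of the core of compound 1. Since the two cores sit together in this assay, the earlier step is the best guide: the step from compound 3 to compound 4 is expected to be a 14-fold higher number from compound 3 to compound 4 (1.14 log units; beyond the scatter), in line with the earlier one, because an at least 12-fold higher number from compound 1 to compound 2 (1.11 log units; beyond the scatter) is large and the cores behave alike. In this assay compound 4 is accordingly expected to give about 60000 nM, with a likely range from 20000 nM to 200000 nM, and most probably only a limit will be reported.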

Compound 4, half-maximal inhibitory concentration: 31400 nM
For compound 4 the middle estimate is 1.9-fold (0.28 log units) above the measured one; low and high end bracket the measured number.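

In this assay methoxy in place of chloro on an aromatic carbon again gives a higher number on the second core, with a 7.2-fold higher number from compound 3 to compound 4 (0.86 log units; beyond the scatter) showing that the direction of the change holds on both cores shown. Compound 2 gives > 50000 nM, which is a limit of the assay and not a number, so this series does not show whether the change has the same size on the two cores: the same change on two cores in this assay, an at least 12-fold higher number (1.11 log units; beyond the scatter) from compound 1 to compound 2 and a 7.2-fold higher number (0.86 log units; beyond the scatter) from compound 3 to compound 4; the limit leaves it open whether they differ. Going by these compounds, the second change on these compounds, chloro in place of fluoro, gives only a floor on the methoxy compounds, an at least 1.5-fold lower number from compound 2 to compound 4 (0.20 log units; that floor lies within the scatter), so it also remains unknown whether that swap carries over from the chloro-bearing core to the methoxy-bearing one: the same change on two cores in this assay, a 1.1-fold higher number (0.05 log units; within the scatter) from compound 1 to compound 3 and an at least 1.5-fold lower number (0.20 log units; that floor lies within the scatter) from compound 2 to compound 4; the limit leaves it open whether they differ.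

The compounds shown leave open how other groups would behave at the place of the methoxy and chloro, such as an amine, a carboxylic acid or a longer chain like butoxy. They also leave open whether the effect of the change would persist with a group other than fluoro or chloro, such as methyl or bromo, on the second aromatic ring.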